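Working notes: from 3-chlorophenyl to 4-chlorophenyl

The compounds below may be only part of what the source reports. "The series", "measured", "known", "first", "only" and "open" are said of these compounds alone.

Measured so far in a functional assay on SK-OV-3 cells (Homo sapiens) for antiproliferative activity, read by MTT assay, with a stated time of 72 h; on this read-out higher numbers stand for weaker inhibition and lower numbers for stronger inhibition
- compound 1 `O=C(CCc1cccc2c1B(O)OC2)Nc1cccc(-c2ccccc2)c1` gives 250 nM
- compound 2 `O=C(CCc1cccc2c1B(O)OC2)Nc1cccc(-c2cccc(Cl)c2)c1` gives 300 nM

Among the measured compounds shown here, compound 2 cannot be told apart from compound 1 on the only two numbers so far, with a 1.2-fold higher number from compound 1 to compound 2 (0.08 log units; within the scatter) as the step between them. Compound 3 `O=C(CCc1cccc2c1B(O)OC2)Nc1cccc(-c2ccc(Cl)cc2)c1` differs from compound 2 in one place, with 4-chlorophenyl in place of 3-chlorophenyl on an aromatic carbon as the whole change, 4-chlorophenyl in place of 3-chlorophenyl on an aromatic carbon. For the measured compounds named here, no measured pair compares these two groups directly. Going by the values given here, the one measured step that bears on the change is chloro in place of hydrogen on an aromatic carbon, seen as a 1.2-fold higher number from compound 1 to compound 2 (0.08 log units; within the scatter) in this assay and lying within the scatter. This is thin evidence, but it gives no reason to look for a large shift in either direction. The expected step is no change at the digits printed from compound 2 to compound 3 (within the scatter) and it is not expected to go beyond the scatter. In this assay compound 3 is estimated at 300 nM with an expected range of 120 nM to 750 nM for now.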

Compound 3, half-maximal inhibitory concentration: 220 nM
The estimate for compound 3 lay 1.4-fold (0.13 log units) above the measured number; the range from low to high includes it.
By their numbers in this assay, from the lowest: compounds 3, 1 and 2 (each within the scatter of the next).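

In this assay, among the compounds shown here, exchanging 3-chlorophenyl for 4-chlorophenyl, two groups with the same atoms joined differently, gives a 1.4-fold lower number from compound 2 to compound 3 (0.13 log units; within the scatter), so this is the first direct comparison of the two chlorinated groups, and the numbers do not separate them. Chloro in place of hydrogen can now be read at a second ring carbon, with a 1.1-fold lower number from compound 1 to compound 3 (0.06 log units; within the scatter) alongside the earlier 1.2-fold higher number from compound 1 to compound 2 (0.08 log units; within the scatter), so neither chloro placement can be told apart from the unsubstituted phenyl of compound 1, and the three compounds form a flat set on this read-out. Nothing measured alongside these numbers offers an explanation for the small differences among them.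

From the compounds shown here alone, it remains open whether this flat picture extends beyond chloro, for instance to an amine or a carboxylic acid at the same ring carbons, where this assay could show a step beyond the scatter. Also unresolved is whether the flatness holds for a longer chain between the amide carbonyl and the shared core, or for a second chloro on the same aromatic ring.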